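Lengthening a chain on a shared core

This account rests on a few compounds, and the source may have more. Where it says the series, first, only, none or still open, it means among the compounds named here.

The series starts with compound 1 `Cn1nc(-c2ccnc(Nc3cccc(S(N)(=O)=O)c3)n2)c2ccccc21`, which in a functional assay on MCF7 cells (Homo sapiens) for antiproliferative activity, read by MTT assay, with a stated time of 72 h (a lower number here means a stronger inhibitor of growth, a higher number a weaker inhibitor of growth), gives 2270 nM. Compound 2 `CCn1nc(-c2ccnc(Nc3cccc(S(N)(=O)=O)c3)n2)c2ccccc21` carries the change methyl in place of hydrogen on a saturated chain carbon bound to an aromatic nitrogen and in this assay compound 2 gives 7260 nM, a step of a 3.2-fold higher number from compound 1 to compound 2 (0.50 log units; beyond the scatter). Compound 3 `CCn1nc(-c2ccnc(Nc3ccc(O)cc3)n2)c2ccccc21` keeps the chain of compound 2 but differs from compound 1 in a way that is not broken down here; in this assay compound 3 gives 5780 nM, a value that sits within the scatter of compound 2. Compound 4 `CCCn1nc(-c2ccnc(Nc3ccc(O)cc3)n2)c2ccccc21` has not been measured yet; it differs from compound 3 by methyl in place of hydrogen on a saturated chain carbon, two bonds along the chain from an aromatic nitrogen. Going by the values given here, this is the same kind of change as the one from compound 1 to compound 2, though the place is not identical: there the saturated chain carbon was bound to an aromatic nitrogen, here it lies two bonds along the chain from an aromatic nitrogen. Because the earlier step of a 3.2-fold higher number from compound 1 to compound 2 (0.50 log units; beyond the scatter) raised the number, a similar but somewhat smaller rise is expected for compound 4, namely a 1.9-fold higher number from compound 3 to compound 4 (0.28 log units; within the scatter). The estimate for compound 4 in this assay is 11000 nM, expected to fall between 4000 nM and 30000 nM.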

Compound 4, concentration for 50% growth inhibition: 3340 nM
Compound 4: the middle estimate sits 3.3-fold (0.52 log units) above what was measured, outside the stated range (below it).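

In this assay, the added methyl gives a 1.7-fold lower number from compound 3 to compound 4 (0.24 log units; within the scatter), so on the core of compound 3 this change cannot be told apart from no effect at all. Set beside the earlier step, it shows that the change does not carry over unaltered from the core of compound 1 to the core of compound 3, and the gap between the two steps is larger than measurement scatter alone would explain: the same change on two cores in this assay, a 3.2-fold higher number (0.50 log units; beyond the scatter) from compound 1 to compound 2 and a 1.7-fold lower number (0.24 log units; within the scatter) from compound 3 to compound 4, 5.5-fold (0.74 log units) apart, beyond the scatter of two such steps

This does not show which difference matters, since the two steps differ both in the core and in the place of the new methyl, and one pair on each core gives no general rule for the series.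

The compounds shown leave open how a longer chain, such as butyl, would behave in place of the propyl chain of compound 4. They also leave open whether a chain ending in an amine or a carboxylic acid would fit either trend.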